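A few compounds are considered here, and "the series" means these few. Any claim that something is new, unique, unknown or untested is made for them only; others in the source may bear on it.

Measured so far in a physicochemical assay for solubility, in phosphate buffer, with a stated time of 2 h; a higher number here means a more soluble compound, a lower number a less soluble compound:
compound 1 `C/C(=N\NC(=N)N)c1sc(-c2ccc(-c3ccccc3)cc2)nc1C`: 2700 nM
compound 2 `Cc1nc(-c2ccc(-c3ccccc3)cc2)sc1-c1nnc(N2CCN(C)CC2)o1`: 45000 nM
compound 3 `Cc1nc(-c2ccc(-c3ccccc3)cc2)sc1-c1nnc(NC(=N)N)o1`: 128000 nM

Compound 3 has the highest number of the three, and both other compounds lie beyond the usual scatter from it. The next compound to be measured is compound 4 `Cc1nc(-c2ccc(-c3ccccc3)cc2)sc1-c1nnc(NC(=N)N2CCN(C)CC2)o1`, which differs from compound 3 in one place: 4-methylpiperazin-1-yl in place of amino on a carbon with a double bond to nitrogen. In words, 4-methylpiperazin-1-yl takes the place of amino on a carbon with a double bond to nitrogen.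

For the measured compounds named here, no measured pair makes exactly this change, so the evidence is indirect. Compound 2 already carries 4-methylpiperazin-1-yl, though on an aromatic carbon, and the step that replaces it was modest: a 2.8-fold higher number from compound 2 to compound 3 (0.45 log units; beyond the scatter). This is the closest guide, and it points to a modest fall from compound 3. The other step, a 47-fold higher number from compound 1 to compound 3 (1.68 log units; beyond the scatter), was large, but it exchanges a different group and says little about this change.

The expected change is a modest fall, a 2.0-fold lower number from compound 3 to compound 4 (0.29 log units; within the scatter). For compound 4 the estimated value is 65000 nM, with an expected range from 20000 nM to 190000 nM. Going by the values given here, the range is kept wide, as only three measured compounds support it.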

Compound 4, solubility: 104000 nM
Compound 4: middle estimate off by 1.6-fold (0.20 log units), on the low side; the range from low to high includes it.
By their numbers in this assay, from the lowest: compound 1; then compound 2; then compounds 4 and 3 (each within the scatter of the next).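

In this assay, 4-methylpiperazin-1-yl can stand in place of amino on a carbon with a double bond to nitrogen, and compound 3 and compound 4 still cannot be told apart: the step is a 1.2-fold lower number from compound 3 to compound 4 (0.09 log units; within the scatter). The entering group has 7 heavy atoms and a six-membered ring, where the leaving group has a single nitrogen. In these two compounds, this far larger group at this place gives no difference beyond the scatter. Compound 2 and compound 4 both carry 4-methylpiperazin-1-yl, yet the step of a 2.3-fold higher number from compound 2 to compound 4 (0.36 log units; beyond the scatter) shows that, for this pair, the number depends on what links that ring to the aromatic carbon, and no measurement shown gives a reason for either result.

As far as these compounds go, it remains open whether a morpholine, a plain piperazine without its methyl, or a short chain such as dimethylamino would give a similar number at this place. From the compounds shown here alone, it is also open whether compound 3 and compound 4 would stay this close in any read-out other than this assay.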